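Pyridin-3-yl ethoxy analogue of compound 1: stability note

A few compounds are considered here, and "the series" means these few. Any claim that something is new, unique, unknown or untested is made for them only; others in the source may bear on it.

The series shares the core of compound 1 `Cc1nc(C)c([C@H](OC(C)(C)C)C(=O)O)c(N2CCC(C)(C)CC2)c1-c1ccc(OCCc2ccc(F)cc2F)cc1` and varies the side chain on an aromatic carbon. In an ADME assay on microsomes from liver (Rattus norvegicus) for metabolic stability, read by LC-MS, tested at 0.5 uM (on this read-out higher numbers stand for a longer-lived compound and lower numbers for a shorter-lived compound), compound 1 gives > 2 h, which is a limit of the assay and not a number. Compound 2 `Cc1nc(C)c([C@H](OC(C)(C)C)C(=O)O)c(N2CCC(C)(C)CC2)c1-c1ccc(CCCc2ccc(F)cc2)cc1` also stops at a limit in this assay, > 2 h. Compound 3 `Cc1nc(C)c([C@H](OC(C)(C)C)C(=O)O)c(N2CCC(C)(C)CC2)c1-c1ccc(OCCc2ccccn2)cc1` gives 1.02 h in this assay. The step that the two limits leave unreadable from compound 1 to compound 2; the steps of an at least 1.9-fold lower number from compound 1 to compound 3 (0.29 log units; that floor lies within the scatter) and an at least 1.9-fold lower number from compound 2 to compound 3 (0.29 log units; that floor lies within the scatter) both run from the limit of > 2 h in this assay, at which 2 of the 3 values shown sit, so only a floor is readable for each.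

Compound 4 `Cc1nc(C)c([C@H](OC(C)(C)C)C(=O)O)c(N2CCC(C)(C)CC2)c1-c1ccc(OCCc2cccnc2)cc1` is the next analogue. The change from compound 1 is pyridin-3-yl in place of 2,4-difluorophenyl on a saturated chain carbon, two bonds along the chain from an oxygen on an aromatic ring. The step that bears on it most directly is the one from compound 1 to compound 3, where a pyridin-2-yl entered at the same place and the number fell by at least the floor given above; the step from compound 2 to compound 3 points the same way. For compound 4 a shorter half-life than that of compound 1 is therefore expected in this assay, an at least 2.0-fold lower number from compound 1 to compound 4 (0.30 log units; that floor lies within the scatter), with its size uncertain. The estimated half-life of compound 4 is 1 h, expected to fall between 0.5 h and 2 h.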

Compound 4, half-life: 0.783 h
Estimate against measurement, compound 4: 1.3-fold (0.11 log units) above, within the range that was stated.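

In this assay, pyridin-3-yl on this saturated chain carbon gives an at least 2.5-fold lower number from compound 1 to compound 4 (0.40 log units; beyond the scatter), the first floor for this replacement of 2,4-difluorophenyl that clears the scatter. The change of the whole side chain to 2-(pyridin-3-yl)ethoxy gives an at least 2.5-fold lower number from compound 2 to compound 4 (0.40 log units; beyond the scatter), and both steps are floors only because each starts from a limit of the assay: the limit of > 2 h in this assay, at which 2 of the 4 values shown sit.

The two pyridine isomers are separated by a 1.3-fold lower number from compound 3 to compound 4 (0.11 log units; within the scatter), so pyridin-2-yl and pyridin-3-yl cannot be told apart at this position on this read-out.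

As far as these compounds go, the true size of the fall from compound 1 stays open, as does the question of whether it follows the entry of the ring nitrogen or the departure of the two fluorines. An unsubstituted phenyl on the same chain would separate those two parts of the change, while a pyridin-4-yl or a fluorine-bearing pyridine would show whether the half-life depends on the nitrogen's place in the ring or can be recovered within the pyridine series.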